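This account rests on a few compounds, and the source may have more. Where it says the series, first, only, none or still open, it means among the compounds named here.

Measured compounds in this series:
compound 1 `O=C1O/C(=C\Cn2cc(-c3ccccc3)nn2)C(OCc2ccccc2)=C1OCc1ccccc1` — > 100000 nM
compound 2 `O=C1NC(O)(CCn2cc(Cc3ccccc3)nn2)C(OCc2ccccc2)=C1OCc1ccccc1` — 39200 nM
compound 3 `CCCc1cn(CCC2(O)C(OCc3ccccc3)=C(OCc3ccccc3)C(=O)N2CCC)nn1` — > 100000 nM

In a functional assay on MCF7 cells (Homo sapiens) for antiproliferative activity, read by MTT assay, with a stated time of 24 h (a higher number here means a weaker inhibitor, a lower number a stronger inhibitor), compound 1 gives > 100000 nM, which is a limit of the assay and not a number. Compound 2 gives 39200 nM in this assay. Compound 3 gives > 100000 nM, again a limit rather than a number. Within the data shown here, compound 1 thus stands at the limit, and per the limit of > 100000 nM in this assay, at which 2 of the 3 values shown sit, it shares that position with one of the other two compounds, so the series so far offers one numerical value and two limits, with no step between measured compounds that differ in a single place.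

Compound 4 `CC(C)(C)c1ccc(-c2cn(C/C=C3\OC(=O)C(OCc4ccccc4)=C3OCc3ccccc3)nn2)cc1` differs from compound 1 by tert-butyl in place of hydrogen on an aromatic carbon. Among the measured compounds shown here, no measured pair carries a change of this kind, so the effect of the tert-butyl group on the six-membered aromatic ring has no precedent here. Given that compound 1 sits at the limit, the step of a number no higher from compound 1 to compound 4 (the limit leaves the size open) is expected to be none beyond the scatter, with compound 4 most likely also reported as a limit. Compound 4 is estimated at 100000 nM, within 30000 nM to 300000 nM.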

Compound 4, half-maximal inhibitory concentration: > 100000 nM
Compound 4: a limit, no number; the forecaster's own chance of this, stated with the estimate: 70%; the middle value lies on the limit itself.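

In this assay compound 4 gives > 100000 nM, a limit of the assay and not a number. Compound 1 stands at the same kind of limit, so no step can be read between the two: the limit of > 100000 nM in this assay, at which 3 of the 4 values shown sit. The compounds shown leave open what tert-butyl in place of hydrogen does to the activity of compound 1.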